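Swapping a fluoro for an acetyl on a shared core

This account rests on a few compounds, and the source may have more. Where it says the series, first, only, none or still open, it means among the compounds named here.

The two measured compounds share one core and differ only in the aryl group attached to it. Compound 1 `c1ccc2c(-c3cn4ccnc4c(-c4ccc5ncn(C6CCCCC6)c5c4)n3)cccc2c1` carries a naphthalen-1-yl group, and in a functional assay on CCRF-CEM cells (Homo sapiens) for inhibition, read by sulforhodamine B assay, with a stated time of 48 h, tested at 10 uM (a lower number here means less inhibition, a higher number more inhibition at the concentration tested (going by the name of the read-out)), compound 1 gives 17.5%. Compound 2 `Fc1ccc(-c2cn3ccnc3c(-c3ccc4ncn(C5CCCCC5)c4c3)n2)cc1` carries a 4-fluorophenyl group instead, and in this assay compound 2 gives 33.4%. The single step measured so far, a number 15.9 percentage points higher from compound 1 to compound 2 (beyond the scatter), leaves compound 2 as the higher of the two numbers shown.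

Compound 3 `CC(=O)c1ccc(-c2cn3ccnc3c(-c3ccc4ncn(C5CCCCC5)c4c3)n2)cc1` is not yet measured. It differs from compound 2 in one place: acetyl in place of fluoro on an aromatic carbon. Within the data shown here, no measured step exchanges one substituent for another on the 4-fluorophenyl group, so the step from compound 1 to compound 2 bears on it only by showing that changing the aryl group moved this read-out modestly. Compound 3 is therefore expected to stay near compound 2, with an estimated step of a number 1.6 percentage points higher from compound 2 to compound 3 (within the scatter) that may well fall within the scatter in either direction. The estimate for compound 3 in this assay is 35%, with a range from 10% to 60%.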

Compound 3, a percentage reported as inhibition, at one concentration (the size of the read-out at that concentration, not a potency): 1.1%
Estimate against measurement, compound 3: 33.9 percentage points above, and the stated range ends above it.
By their numbers in this assay, from the lowest: compound 3; then compound 1; then compound 2.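

At this place, on an aromatic carbon para to a large group, the substituent alone proves able to move the read-out in this assay: acetyl in place of fluoro gives a number 32.3 percentage points lower from compound 2 to compound 3 (beyond the scatter), a large step, whereas the earlier exchange of the whole aryl group was modest. The phenyl ring by itself therefore does not secure the higher number of compound 2, for the comparison with the naphthalen-1-yl group reverses once the ring carries acetyl, giving a number 16.4 percentage points lower from compound 1 to compound 3 (beyond the scatter). Nothing available here accounts for the size or direction of this change.

With only fluoro and acetyl shown on this ring, it remains open whether the low number of compound 3 is particular to acetyl or would also appear with other groups at this place, such as a methoxy group, an amine or a carboxylic acid. From the compounds shown here alone, it is also open whether the same exchange would have a similar effect on another aryl group, or with a group other than cyclohexyl on the shared core.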